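A few compounds are considered here, and "the series" means these few. Any claim that something is new, unique, unknown or untested is made for them only; others in the source may bear on it.

Two compounds share one core and differ only in the aryl substituent and the chain to the sulfamide. Compound 1 `COC(=O)c1ccc(-c2cc(N3CCC(CNS(N)(=O)=O)CC3)ncn2)cc1` carries a methoxycarbonyl; in a functional assay on MCF7 cells (Homo sapiens) for antiproliferative activity, read by sulforhodamine B assay, with a stated time of 48 h (a higher number here means a weaker inhibitor of growth, a lower number a stronger inhibitor of growth), compound 1 gives 17700 nM. Compound 2 `NS(=O)(=O)NCCC1CCN(c2cc(-c3ccc(C(F)(F)F)cc3)ncn2)CC1` carries a trifluoromethyl and a chain one carbon longer; in this assay compound 2 gives 15200 nM. Compound 2 has the lower of the two numbers, but its gap to compound 1 lies within the scatter, so neither can be called the stronger inhibitor of growth.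

Compound 3 `COC(=O)c1ccc(-c2cc(N3CCC(CCNS(N)(=O)=O)CC3)ncn2)cc1` keeps the longer chain of compound 2 and takes the change (methoxycarbonyl in place of trifluoromethyl on an aromatic carbon). Within the data shown here, no measured pair isolates this exchange. Since compound 1 with the methoxycarbonyl gives 17700 nM, close to compound 2, the step of a 1.1-fold higher number from compound 2 to compound 3 (0.02 log units; within the scatter) is expected to stay within the scatter. Compound 3 is therefore estimated at 16000 nM, with a range from 7000 nM to 36000 nM.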

Compound 3, concentration for 50% growth inhibition: 17600 nM
For compound 3 the middle estimate is 1.1-fold (0.04 log units) below the measured one; low and high end bracket the measured number.
By their numbers in this assay, from the lowest: compounds 2, 3 and 1 (each within the scatter of the next).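

In this assay, the exchange of trifluoromethyl for methoxycarbonyl on an aromatic carbon, para to a large group, can now be read alone: a 1.2-fold higher number from compound 2 to compound 3 (0.06 log units; within the scatter) is the whole effect with the longer chain held constant. The chain can also be read alone, since with the methoxycarbonyl kept, a 1.0-fold lower number from compound 1 to compound 3 (0.00 log units; within the scatter) follows from (sulfamoylamino)methyl in place of sulfamoylamino on a saturated chain carbon bound to a saturated ring carbon. Both steps lie within the scatter, so the closeness of compound 1 and compound 2 does not conceal two large opposing steps, and nothing on hand offers an explanation for these results.

The compounds shown leave open whether a carboxylic acid, a nitrile or an amine on this aromatic carbon would give a number beyond the scatter. They also leave open whether a longer chain to the sulfamide would do so.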